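A few compounds are considered here, and "the series" means these few. Any claim that something is new, unique, unknown or untested is made for them only; others in the source may bear on it.

Measured so far in a functional assay on the whole organism for inhibition, with Rattus norvegicus as the target, read by paw edema, at a dose of 100 mg/kg by the oral route; a lower number here means less inhibition, a higher number more inhibition at the dose given (going by the name of the read-out):

- compound 1 `Cc1ccc(NC(=O)c2c(O)c3cccnc3n(-c3ccccc3)c2=O)cc1` gives -3.5%
- compound 2 `Nc1ccc(NC(=O)c2c(O)c3cccnc3n(-c3ccccc3)c2=O)cc1` gives -5.5%
- compound 3 `COc1cccc(NC(=O)c2c(O)c3cccnc3n(-c3ccccc3)c2=O)c1` gives 5.7%

Compound 3 carries the largest of the three numbers, but its standing is mixed: the step of a number 9.2 percentage points higher from compound 1 to compound 3 (within the scatter), while the step of a number 11.2 percentage points higher from compound 2 to compound 3 (beyond the scatter). Among the compounds with values here, the only other step, a number 2 percentage points lower from compound 1 to compound 2 (within the scatter), is likewise small. All three measured compounds lie close together, and none of the changes on the amide-type nitrogen has moved the read-out far.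

Compound 4 `COc1ccccc1NC(=O)c1c(O)c2cccnc2n(-c2ccccc2)c1=O` is next. The change is 2-methoxyphenyl in place of 3-methoxyphenyl on an amide-type nitrogen. Within the data shown here, the steps that bear on it are those which also exchanged the aryl group on the amide-type nitrogen, from compound 1 to compound 3 and from compound 2 to compound 3, and both were small. Among the measured compounds shown here, no measured step moves a methoxy from one ring position to another, so nothing points to a direction. The expected step is therefore a number 2.7 percentage points lower from compound 3 to compound 4 (within the scatter), nothing beyond the scatter. Compound 4 is estimated at 3%, in the range -10% to 16%.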

Compound 4, a percentage reported as inhibition, in the whole organism at one dose (the size of the read-out at that dose, not a potency): 8.1%
For compound 4 the middle estimate is 5.1 percentage points below the measured one; measured number inside the range.
By their numbers in this assay, from the lowest: compounds 2, 1, 3 and 4 (each within the scatter of the next, the first and the last beyond it).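

In this assay, the exchange of 3-methoxyphenyl for 2-methoxyphenyl on the amide-type nitrogen gives a number 2.4 percentage points higher from compound 3 to compound 4 (within the scatter), so this change of methoxy ring position does not separate the two compounds. The 2-methoxyphenyl compound stands clear of both aryl amides without a methoxy, with a number 13.6 percentage points higher from compound 2 to compound 4 (beyond the scatter) and a number 11.6 percentage points higher from compound 1 to compound 4 (beyond the scatter), whereas the 3-methoxyphenyl compound stood clear only of compound 2, and these steps remain modest. Nothing available explains these differences.

Still open, as far as these compounds go, is whether 4-methoxyphenyl would complete the methoxy set at this position with a similar read-out, and whether a benzyl group or a longer alkyl chain on the amide-type nitrogen would move it further. Also open, from the compounds shown here alone, is whether a carboxylic acid on the aryl ring would give a larger step than any seen here.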